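The compounds below may be only part of what the source reports. "The series", "measured", "known", "first", "only" and "open" are said of these compounds alone.

Values in a functional assay on HT-29 cells (Homo sapiens) for cytotoxicity, read by MTT assay, with a stated time of 72 h; on this read-out higher numbers stand for weaker inhibition and lower numbers for stronger inhibition:
- compound 1 `O=C(CN1CCN(c2nnc(Cc3ccncc3)c3ccccc23)CC1)Nc1cccc(Br)c1`: 1350 nM
- compound 2 `O=C(CN1CCN(c2nnc(Cc3ccccc3)c3ccccc23)CC1)Nc1ccc(F)c(F)c1`: 9510 nM
- compound 3 `O=C(CN1CCN(c2nnc(Cc3ccccc3)c3ccccc23)CC1)Nc1cc(C(F)(F)F)ccc1Cl`: 66800 nM

Compound 1 has the lowest number of the three. Compound 4 `O=C(CN1CCN(c2nnc(Cc3ccncc3)c3ccccc23)CC1)Nc1ccc(F)c(Cl)c1` carries 3-chloro-4-fluorophenyl in place of 3-bromophenyl on an amide-type nitrogen. Among the compounds with values here, the only measured step at this nitrogen is a 7.0-fold higher number from compound 2 to compound 3 (0.85 log units; beyond the scatter). It involves other groups and a core that differs from that of compound 1, so it gives only a rough scale. Compound 2, with 3,4-difluorophenyl on that nitrogen, stands at 9510 nM, which leans the expectation towards a higher number. The estimated change is a 2.2-fold higher number from compound 1 to compound 4 (0.35 log units; beyond the scatter), a modest one. Compound 4 is expected at 3000 nM, with an estimated range of 900 nM to 10000 nM.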

Compound 4, half-maximal inhibitory concentration: 880 nM
Beside the measured number, compound 4's estimate is 3.4-fold (0.53 log units) above it; measured number outside the range, below it.
By their numbers in this assay, from the lowest: compounds 4 and 1 (each within the scatter of the next); then compound 2; then compound 3.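

In this assay, exchanging 3-bromophenyl for 3-chloro-4-fluorophenyl on the amide-type nitrogen gives a 1.5-fold lower number from compound 1 to compound 4 (0.19 log units; within the scatter), so the two groups are not told apart on this core. Within the data shown here, this is the only step at this nitrogen on the core of compound 1, and it shows that the halogen pattern on the phenyl can change here without a difference beyond the scatter. No measurement available here explains this result.

Still open, on these data alone, is how a phenyl carrying a methoxy group or a nitrile, rather than halogens, would read at this nitrogen. Also open, as far as these compounds go, is whether the same phenyl group would read alike on the cores of compound 1 and compound 2.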